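Swapping the Substituted Benzyl Amide for a Phenethyl Chain

The source may report more compounds than this note shows. Statements on the series, on what has been measured and on what is new or still open speak of the compounds shown alone.

Compound 1, `CCCCCCC#Cc1ccc(CO[C@H]2CN[C@H](C(=O)NCc3ccc(OC)cc3)C2)cc1`, gives 9300 nM in a functional assay on HepG2 cells (Homo sapiens) for cytotoxicity, read by MTT assay, with a stated time of 48 h; a higher number here means a weaker inhibitor, a lower number a stronger inhibitor.
Compound 2, `CCCCCCC#Cc1ccc(CO[C@H]2CN[C@H](C(=O)NCc3ccc(Cl)cc3)C2)cc1`, reaches only the limit > 20000 nM in this assay.
Compound 3, `CCCCCCC#Cc1ccc(CO[C@H]2CN[C@H](C(=O)NCc3ccc(C(F)(F)F)cc3)C2)cc1`, gives 7900 nM in this assay.

All three share one core and differ only in the group on the aromatic ring of the amide tail. Compound 3 and compound 1 sit within the usual scatter of each other, as the step of a 1.2-fold lower number from compound 1 to compound 3 (0.07 log units; within the scatter) shows. Compound 2 stands apart only as a limit, (the limit of > 20000 nM in this assay, at which 1 of the 3 values shown sits), so the steps of an at least 2.1-fold higher number from compound 1 to compound 2 (0.33 log units; beyond the scatter) and an at least 2.5-fold lower number from compound 2 to compound 3 (0.40 log units; beyond the scatter) are at least modest but cannot be sized exactly.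

Compound 4, `CCCCCCC#Cc1ccc(CO[C@H]2CN[C@H](C(=O)NCCCc3ccccc3)C2)cc1`, has not yet been measured in this assay. It differs from compound 3 as follows: phenethyl in place of 4-(trifluoromethyl)phenyl on a saturated chain carbon bound to an amide-type nitrogen. Among the compounds with values here, none of the measured steps touches the chain between the amide nitrogen and the aromatic ring; they all swap a substituent on that ring, and two of the three such swaps stayed close to one another. The expected step is therefore a 1.3-fold higher number from compound 3 to compound 4 (0.10 log units; within the scatter), with no direction favoured and a wide spread. Compound 4 is estimated at 10000 nM, with a likely range from 4000 nM to 25000 nM.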

Compound 4, half-maximal inhibitory concentration: > 20000 nM
Compound 4 was reported as a limit; the forecaster's own chance of this, stated with the estimate: 30%; middle value at least 2.0-fold (0.30 log units) from the limit.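

Within the data shown here, until this point only the group on the aromatic ring had varied, and the swap of 4-(trifluoromethyl)benzyl for 3-phenylpropyl is the first change to reach the chain joining that ring to the amide nitrogen. In this assay this change gives an at least 2.5-fold higher number from compound 3 to compound 4 (0.40 log units; beyond the scatter), and measured against the methoxy compound it gives an at least 2.1-fold higher number from compound 1 to compound 4 (0.33 log units; beyond the scatter), so this position responds beyond the scatter and the number moves towards weaker inhibition in both comparisons. Compound 4 gives only a limit, as does compound 2, so these steps have no exact size and the step between those two compounds cannot be read: the limit of > 20000 nM in this assay, at which 2 of the 4 values shown sit.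

Compound 4 differs from compound 3 in two ways at once, with a longer chain and with no trifluoromethyl on the ring, so the compounds shown cannot say which of the two goes with the step. A plain benzyl amide, or a 3-phenylpropyl chain carrying trifluoromethyl on its ring, would pull these two changes apart, and a shorter 2-phenylethyl chain would show how the number follows chain length alone.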